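The source may report more compounds than this note shows. Statements on the series, on what has been measured and on what is new or still open speak of the compounds shown alone.

The shared core carries two chlorinated styryl arms and a phenyl ring on the saturated carbon, and the three measured compounds differ only in where the chlorine atoms sit. Compound 1 `CC1=CSC2=NC(/C=C/c3cccc(Cl)c3)=C(C(=O)/C=C/c3cccc(Cl)c3)C(c3ccccc3)N12` gives 286 ug/mL in an ADME assay on Vero cells (Chlorocebus sabaeus) for cytotoxicity, read by fluorescence and resazurin assay, with a stated time of 72 h; on this read-out higher numbers stand for lower toxicity in this test and lower numbers for higher toxicity in this test. Compound 2 `CC1=CSC2=NC(/C=C/c3ccccc3Cl)=C(C(=O)/C=C/c3ccccc3Cl)C(c3ccccc3)N12` gives 206 ug/mL in this assay. Compound 3 `CC1=CSC2=NC(/C=C/c3ccccc3Cl)=C(C(=O)/C=C/c3ccccc3Cl)C(c3ccc(Cl)cc3)N12` gives 430 ug/mL in this assay. Compound 1 and compound 2 have the same atoms joined differently, and the difference between the two cores is not broken down here; their two numbers lie within the usual scatter of each other.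

Between compound 2 and compound 3 the change is chloro in place of hydrogen on an aromatic carbon, and it made the step of a 2.1-fold higher number from compound 2 to compound 3 (0.32 log units; beyond the scatter), a modest shift toward a higher number beyond the scatter.

Compound 4 `CC1=CSC2=NC(/C=C/c3cccc(Cl)c3)=C(C(=O)/C=C/c3cccc(Cl)c3)C(c3ccc(Cl)cc3)N12` has not yet been measured. It stands to compound 1 as compound 3 stands to compound 2: the change is chloro in place of hydrogen on an aromatic carbon, with the same place described word for word, so it is the same change made on the other core.

The expectation for compound 4 rests on a single precedent, the step of a 2.1-fold higher number from compound 2 to compound 3 (0.32 log units; beyond the scatter), transferred to the core of compound 1. On that basis compound 4 is expected to show a 2.0-fold higher number from compound 1 to compound 4 (0.29 log units; within the scatter) in this assay, a step of about the same size as the earlier one. Going by the values given here, compound 4 is therefore estimated at 560 ug/mL, with a range from 300 ug/mL to 1000 ug/mL, the width reflecting that only one example of this change is available.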

Compound 4, half-maximal cytotoxic concentration: 317 ug/mL
For compound 4 the middle estimate is 1.8-fold (0.25 log units) above the measured one; the range from low to high includes it.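

In this assay, the change from phenyl to 4-chlorophenyl gives a 1.1-fold higher number from compound 1 to compound 4 (0.04 log units; within the scatter), so on the core of compound 1 the added chloro leaves a number that cannot be told apart from that of the parent. Set beside the earlier step, the two results do not separate from each other: the same change on two cores in this assay, a 2.1-fold higher number (0.32 log units; beyond the scatter) from compound 2 to compound 3 and a 1.1-fold higher number (0.04 log units; within the scatter) from compound 1 to compound 4, 1.9-fold (0.27 log units) apart, within the scatter of two such steps

Going by these compounds alone, this shows that the two cores give no firm sign of disagreeing about this change, but it does not show that the change carries over with the same size, as only one of the two steps stands beyond the scatter and the other does not. With just two matched pairs, the series can neither confirm a shared effect of the chloro nor establish that the effect depends on the core.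

The compounds shown leave open whether another group on the same aromatic carbon, such as fluoro, methoxy or an amine, would give a step that holds across both cores. They also leave open how this change would behave on a core whose styryl arms carry no chlorine, or carry a methoxy group in its place.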